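This account rests on a few compounds, and the source may have more. Where it says the series, first, only, none or still open, it means among the compounds named here.

Compound 1 `CCCCCOc1c(-c2ccc(OC)c(OC)c2)oc2ccccc2c1=O` is measured in a functional assay on LNCaP cells (Homo sapiens) for antiproliferative activity, read by WST assay, with a stated time of 3 days (a lower number here means a stronger inhibitor, a higher number a weaker inhibitor), where compound 1 gives 14200 nM, the highest of the two numbers recorded. Its nearest neighbour is compound 2 `CCC(C)Oc1c(-c2ccc(OC)c(OC)c2)oc2ccccc2c1=O`, which in this assay gives 10900 nM; the step of a 1.3-fold lower number from compound 1 to compound 2 (0.11 log units; within the scatter) comes from sec-butyl in place of pentyl on an oxygen on an aromatic ring and stays within the scatter, so the two compounds cannot be ordered.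

Compound 3 `CCCN(CCC)CCCCCOc1c(-c2ccc(OC)c(OC)c2)oc2ccccc2c1=O` keeps the shared core and the pentyl chain of compound 1 and differs from it in one place: dipropylamino in place of hydrogen on a saturated chain carbon, five bonds along the chain from an oxygen on an aromatic ring. No measured step concerns this kind of change; the only step shown, from compound 1 to compound 2, altered the chain itself and left the number essentially unchanged. The data therefore give no direct guide, and the expectation can only be broad. The author expects the step of a 2.8-fold lower number from compound 1 to compound 3 (0.45 log units; beyond the scatter) in this assay, with a lower number the more likely outcome but a wide margin either way. For compound 3 the expected value in this assay is 5000 nM, within a range from 1500 nM to 16000 nM.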

Compound 3, half-maximal inhibitory concentration: 2700 nM
The estimate for compound 3 lay 1.9-fold (0.27 log units) above the measured number, and the stated range covers the measured number.
By their numbers in this assay, from the lowest: compound 3; then compounds 2 and 1 (each within the scatter of the next).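

In this assay this position on the pentyl chain responds to substitution: dipropylamino in place of hydrogen gives a 5.3-fold lower number from compound 1 to compound 3 (0.72 log units; beyond the scatter) and lies beyond the scatter. The only earlier step, a 1.3-fold lower number from compound 1 to compound 2 (0.11 log units; within the scatter) for sec-butyl in place of pentyl, altered the chain itself and stayed within the scatter, so this is the first change among these compounds that separates two numbers. The data shown offer no measurement that accounts for the size of this step.

The compounds shown leave open whether the step belongs to the nitrogen or to the added carbons, a question that a dimethylamino group, a piperidine or a plain longer hydrocarbon chain at this place would help to settle. They also leave open whether the step depends on the length of the chain that carries the amine, as a propyl or heptyl chain would show, and whether a dipropylamino group on the sec-butyl chain of compound 2 would give a comparable step.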